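From Bromo to Methylsulfanyl: A Change Without a Known Number

This account rests on a few compounds, and the source may have more. Where it says the series, first, only, none or still open, it means among the compounds named here.

Compound 1 `O=c1c(-c2nn[nH]n2)c[nH]c2c(Br)cccc12` was tested in a functional assay on the whole organism (strain Sprague-Dawley) for inhibition, with Rattus norvegicus as the target; on this read-out lower numbers stand for an effect already at smaller amounts and higher numbers for an effect only at larger amounts of compound. In this assay compound 1 stands only at a limit, > 10 mg/kg, so no actual number is known for it. Compound 2 `Cc1cccc2cc(C(=O)O)cnc12` also gave only a limit in this assay, > 25 mg/kg. Compound 3 `CSc1cccc2c(=O)c(-c3nn[nH]n3)c[nH]c12` differs from compound 1 by methylsulfanyl in place of bromo on an aromatic carbon. Since the two values already shown are limits rather than numbers, no measured step sets a scale here. The expected step is a number no higher from compound 1 to compound 3 (the limit leaves the size open), which does not go beyond the usual scatter. In this assay compound 3 is estimated at about 10 mg/kg, with a range from 3 mg/kg to 30 mg/kg, and quite possibly again only a limit.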

Compound 3, minimum effective dose: 25 mg/kg
Beside the measured number, compound 3's estimate is 2.5-fold (0.40 log units) below it, and the stated range covers the measured number.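

No step can be read from compound 1 to compound 3, as compound 1 has only a limit and not a number. The compounds shown leave open whether methylsulfanyl in place of bromo changes the minimum effective dose at all.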